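The source may hold more compounds than are shown below. What is called first, only, known or untested is meant among the compounds shown, and "the series" means these compounds.

Compound 1 `Cc1nccc(-c2ccccc2)c1C(=O)N(C)Cc1cc(C(F)(F)F)cc(C(F)(F)F)c1`: 98 nM
Compound 2 `Cc1c(C(=O)NCc2cc(C(F)(F)F)cc(C(F)(F)F)c2)c(-c2ccccc2)cc[n+]1[O-]`: 342 nM

Both were tested in an assay on CHO cells for displacement of a labelled ligand from Substance-P receptor (Homo sapiens), with a stated time of 90 min; a lower number here means a stronger inhibitor, a higher number a weaker inhibitor. Of the two numbers, compound 1 has the lower one, so it is the stronger inhibitor of the pair; compound 2 gives a higher number, and the gap between the two lies beyond the usual scatter of repeated measurements. Compound 3 `Cc1nc(N2CCN(C)CC2)cc(-c2ccccc2)c1C(=O)N(C)Cc1cc(C(F)(F)F)cc(C(F)(F)F)c1` has not yet been measured. It is built from compound 1 by a single change: 4-methylpiperazin-1-yl in place of hydrogen on an aromatic carbon. For the measured compounds named here, nothing among the measured compounds shows directly what such a change does, as no measured pair differs in just this way. The change adds a sizable group to the shared core while leaving the rest of compound 1 untouched. The expectation for compound 3 is a modest step rather than a large one, and the expected step is a 1.6-fold lower number from compound 1 to compound 3 (0.21 log units; within the scatter), toward a somewhat lower number. Compound 3 is expected to give about 60 nM in this assay, with an estimated range from 12 nM to 300 nM.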

Compound 3, half-maximal inhibitory concentration: 4.8 nM
The estimate for compound 3 lay 13-fold (1.10 log units) above the measured number; measured number below the stated range.
By their numbers in this assay, from the lowest: compound 3; then compound 1; then compound 2.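

In this assay, putting 4-methylpiperazin-1-yl in place of hydrogen on the aromatic carbon next to the ring nitrogen gives a 20-fold lower number from compound 1 to compound 3 (1.31 log units; beyond the scatter). For the compounds shown here, no earlier pair showed what a change at this position does, and this one shows that the position accepts a sizable group, a six-membered non-aromatic ring with 2 hetero atoms, and that the number then falls rather than rises, so this carbon is a place where a single change can move the number a long way. Nothing measured here says why the number falls so far, so the size of the step stands as an observation only.

Going by these compounds, it remains open which part of the 4-methylpiperazin-1-yl group matters: a morpholine ring, with oxygen in place of the methyl-bearing nitrogen, or a piperidine ring, with carbon there, on this same carbon would begin to separate the ring from its second nitrogen. A small open-chain amine such as dimethylamino would show whether a ring is needed at all, and a methoxy group whether any nitrogen is.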